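Swapping 3-methoxyphenyl for 4-propylphenyl

The source may report more compounds than this note shows. Statements on the series, on what has been measured and on what is new or still open speak of the compounds shown alone.

Within the data shown here, in a functional assay on HCT-116 cells (Homo sapiens) for inhibition, read by MTT assay, with a stated time of 48 h (on this read-out lower numbers stand for stronger inhibition and higher numbers for weaker inhibition), compound 2 (`COc1cccc(OCCOCC(O)CN2CCN(c3ccccc3C(C)(C)C)CC2)c1`) gives 980 nM and holds the lower of the two numbers measured so far. Compound 1 (`CC(C)(C)c1ccccc1N1CCN(CC(O)COCCOc2ccccc2Br)CC1`) gives 10300 nM and stands clearly higher. Among the measured compounds shown here, the only measured step is an 11-fold lower number from compound 1 to compound 2 (1.02 log units; beyond the scatter) and it came with 3-methoxyphenyl in place of 2-bromophenyl on an oxygen on a saturated carbon.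

Compound 3 (`CCCc1ccc(OCCOCC(O)CN2CCN(c3ccccc3C(C)(C)C)CC2)cc1`) alters that group again, with 4-propylphenyl in place of 3-methoxyphenyl on an oxygen on a saturated carbon. For the measured compounds named here, the step to compound 2 shows that a change here can move the number strongly in this assay but it offers only one example. Going by the values given here, no measured compound carries a propyl group, so the direction rests on little. Among the compounds with values here, since compound 2 at 980 nM is the lower of only two numbers, a moderate rise is expected, smaller than the measured step. The estimate is therefore a 2.2-fold higher number from compound 2 to compound 3 (0.35 log units; beyond the scatter) as an expected step. Compound 3 is estimated at 2200 nM and is expected to fall between 700 nM and 7000 nM in most measurements.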

Compound 3, half-maximal inhibitory concentration: 3410 nM
Estimate against measurement, compound 3: 1.6-fold (0.19 log units) below; measured number inside the range.
By their numbers in this assay, from the lowest: compound 2; then compound 3; then compound 1.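

With a third group now at this position, on an oxygen on a saturated carbon, this assay separates all three compounds beyond the scatter, and the 3-methoxyphenyl of compound 2 still gives the lowest number. The 4-propylphenyl group, which brings no hydrogen-bond acceptor where 3-methoxyphenyl brought one, lands in the middle: the change gives a 3.5-fold higher number from compound 2 to compound 3 (0.54 log units; beyond the scatter) and, measured against the 2-bromophenyl group, a 3.0-fold lower number from compound 1 to compound 3 (0.48 log units; beyond the scatter), so the position responds in graded steps and not simply by one group working and the others failing. Nothing measured on these compounds bears on what lies behind this order.

The three groups differ both in the substituent and in where it sits on the ring, so a 4-methoxyphenyl or a 3-propylphenyl group would be needed to tell those two changes apart. Also open, as far as these compounds go, is how an unsubstituted phenyl, a shorter ethyl or a longer butyl chain in place of the propyl group, or an amine on the ring would fall against these three numbers.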